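From Benzyl to 4-Fluorophenyl on an Aromatic Nitrogen

This account rests on a few compounds, and the source may have more. Where it says the series, first, only, none or still open, it means among the compounds named here.

Of the compounds shown here, three built on one shared core have been tested in an ADME assay on HeLa cells (Homo sapiens) for cytotoxicity, read by MTT assay; on this read-out higher numbers stand for weaker inhibition and lower numbers for stronger inhibition. Compound 1 `COc1ccc(C[C@H]2COC(=O)[C@@H]2Cc2ccc(OCC(=O)Nc3ccccc3)c(OC)c2)cc1OC` carries a phenylcarbamoyl group; in this assay compound 1 gives >= 600000 nM, which is a limit of the assay rather than a number. Compound 2 `COc1ccc(-n2cc(COc3ccc(C[C@H]4C(=O)OC[C@@H]4Cc4ccc(OC)c(OC)c4)cc3OC)nn2)cc1` carries a 4-methoxyphenyl group on an aromatic nitrogen; in this assay compound 2 gives >= 600000 nM, again a limit. Compound 3 `COc1ccc(C[C@H]2COC(=O)[C@@H]2Cc2ccc(OCc3cn(Cc4ccccc4)nn3)c(OC)c2)cc1OC` is the only one of the three with a number: in this assay compound 3 gives 346000 nM. Both measured steps end at compound 3: an at least 1.7-fold lower number from compound 1 to compound 3 (0.23 log units; that floor lies within the scatter) and an at least 1.7-fold lower number from compound 2 to compound 3 (0.23 log units; that floor lies within the scatter). Both rest on (the limit of >= 600000 nM in this assay, at which 2 of the 3 values shown sit), so neither step is known to reach beyond the scatter.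

Compound 4 `COc1ccc(C[C@H]2COC(=O)[C@@H]2Cc2ccc(OCc3cn(-c4ccc(F)cc4)nn3)c(OC)c2)cc1OC` differs from compound 3 in one place: 4-fluorophenyl in place of benzyl on an aromatic nitrogen. The closest comparison is compound 2, which also carries an aryl group on an aromatic nitrogen and sits at the limit, and the step of an at least 1.7-fold lower number from compound 2 to compound 3 (0.23 log units; that floor lies within the scatter) was small. Putting an aryl group back on that nitrogen is expected to move the number toward the limit again, as a 1.4-fold higher number from compound 3 to compound 4 (0.16 log units; within the scatter). Compound 4 is expected to give 500000 nM, within 250000 nM to 1000000 nM, with a fair chance that only a limit is reported.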

Compound 4, half-maximal inhibitory concentration: >= 600000 nM
Compound 4: a limit, no number; the forecaster's own chance of this, stated with the estimate: 50%; middle value at least 1.2-fold (0.07 log units) away from the limit.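

Placing 4-fluorophenyl instead of benzyl on the aromatic nitrogen gives an at least 1.7-fold higher number from compound 3 to compound 4 (0.23 log units; that floor lies within the scatter), so only a floor is known for this change, and that floor alone does not separate it from ordinary scatter. With an aryl ring bound directly to that nitrogen, as 4-methoxyphenyl in compound 2 and 4-fluorophenyl in compound 4, no number appears in this assay, and among the triazole compounds shown only the benzyl group of compound 3 gives one, at 346000 nM. The steps to compound 4 from compound 1 and from compound 2 cannot be read, and the series offers little resolution in this direction: the limit of >= 600000 nM in this assay, at which 3 of the 4 values shown sit.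

Still open, from the compounds shown here alone, is whether benzyl itself matters or only the carbon that sets its ring away from the nitrogen, a question that 4-fluorobenzyl or a longer chain such as 2-phenylethyl would address. Also open, going by these compounds, is whether any group on this nitrogen, for instance a chain ending in an amine or a carboxylic acid, gives a number that stands clearly apart from that of compound 3.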